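This account rests on a few compounds, and the source may have more. Where it says the series, first, only, none or still open, it means among the compounds named here.

Values so far in a functional assay on the whole organism for positive allosteric modulation, with Mus musculus as the target; a lower number here means that less compound is needed, a higher number that more compound is needed for the effect

Compound 1 `CCC(=O)N(c1cccc(Cl)c1)C1CCCC1N(C)C` gives 0.4 mg/kg
Compound 2 `CCC(=O)N(c1ccc(F)c(Cl)c1)C1CCCC1N(C)C` gives 0.2 mg/kg
Compound 3 `CCC(=O)N(c1cc(Cl)cc(Cl)c1)C1CCCC1N(C)C` has no value yet

In this assay, among the measured compounds shown here, compound 1 stands within the usual scatter of compound 2, the only other compound measured, so the two values cannot be told apart. Compound 3 differs from compound 1 by one change chloro in place of hydrogen on an aromatic carbon which is chloro in place of hydrogen on an aromatic carbon, meta to a chloro group and meta to a large group. For the measured compounds named here, only one measured step bears on this, and only loosely: fluoro in place of hydrogen on an aromatic carbon gave a 2.0-fold lower number from compound 1 to compound 2 (0.30 log units; within the scatter) and it brought in a different halogen. Going by the values given here, no measured compound shows what a second chloro group does. From the compounds shown here alone, because a 2.0-fold lower number from compound 1 to compound 2 (0.30 log units; within the scatter) stayed within the scatter, no step beyond the scatter is expected in this assay and any direction remains open. The estimated step is a 1.3-fold lower number from compound 1 to compound 3 (0.12 log units; within the scatter) and it is no more than an expectation. In this assay the estimate for compound 3 is 0.3 mg/kg with 0.1 mg/kg to 0.9 mg/kg as its expected range.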

Compound 3, dose for half-maximal effect: 0.9 mg/kg
For compound 3 the middle estimate is 3.0-fold (0.48 log units) below the measured one, and the stated range covers the measured number.
By their numbers in this assay, from the lowest: compounds 2 and 1 (each within the scatter of the next); then compound 3.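

In this assay, the added chloro, placed on an aromatic carbon meta to a chloro group and meta to a large group, gave the only step among the compounds shown that lies beyond the scatter (a 2.3-fold higher number from compound 1 to compound 3 (0.35 log units; beyond the scatter)). This position therefore tolerates no free substitution: a second chloro group here moves the number measurably away from that of compound 1, towards more compound being needed, although the step is modest and rests on one pair. The data at hand offer no measurement that would explain this step.

What a fluoro, a methyl, a methoxy or a nitrile group would do at this same place remains open, so the compounds shown cannot say whether the higher number belongs to chloro alone or would follow any group there. Among the compounds shown here, it is also open whether the step depends on the chloro group already on the ring, since this substitution is seen only with that group present.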